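The source may report more compounds than this note shows. Statements on the series, on what has been measured and on what is new or still open speak of the compounds shown alone.

Measured so far:
compound 1, `CC(=O)c1ccc(-c2cn3ccnc3c(-c3ccc4ncn(C5CCCCC5)c4c3)n2)cc1` — 2.65%
compound 2, `Clc1ccc(-c2cn3ccnc3c(-c3ccc4ncn(C5CCCCC5)c4c3)n2)cc1` — 15.6%

Among the compounds with values here, in a functional assay on HL-60 cells (Homo sapiens) for inhibition, read by sulforhodamine B assay, with a stated time of 48 h, tested at 10 uM (on this read-out higher numbers stand for more inhibition at the one concentration tested (going by the name of the read-out) and lower numbers for less inhibition), compound 2 stands highest of the two numbers, and the only step available in the set is a number 13 percentage points higher from compound 1 to compound 2 (beyond the scatter), a modest rise beyond the scatter tied to the swap of acetyl for chloro on the aromatic carbon.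

Compound 3, `Brc1ccc(-c2cn3ccnc3c(-c3ccc4ncn(C5CCCCC5)c4c3)n2)cc1`, is not yet measured. It differs from compound 2 by bromo in place of chloro on an aromatic carbon. Within the data shown here, no measured step bears on a change of one halogen for another; the single step concerns a different substituent and gives no direction for this one. With the same shared core and the halogen kept at the same place, no step beyond the scatter is expected in this assay in either direction.

Compound 3 is therefore expected near 18%, with a range of 5% to 35%. The step of a number 2.4 percentage points higher from compound 2 to compound 3 (within the scatter) is expected to stay within the scatter.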

Compound 3, a percentage reported as inhibition, at one concentration (the size of the read-out at that concentration, not a potency): 23.2%
The estimate for compound 3 lay 5.2 percentage points below the measured number; the range from low to high includes it.
By their numbers in this assay, from the lowest: compound 1; then compounds 2 and 3 (each within the scatter of the next).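

In this assay, bromo in place of chloro on this aromatic carbon, para to a large group, gives a number 7.6 percentage points higher from compound 2 to compound 3 (within the scatter), so this read-out does not separate the two halogens at this position. Bromo in place of acetyl gives a number 20.6 percentage points higher from compound 1 to compound 3 (beyond the scatter), which means that the rise seen in a number 13 percentage points higher from compound 1 to compound 2 (beyond the scatter) is no longer confined to a single halogen, although it still rests on only one acetyl compound. Nothing available bears on why the halogens and acetyl differ here.

Still open, from the compounds shown here alone, is whether fluoro, iodo, an amine or a carboxylic acid at this position would sit with the two halogens, with acetyl or elsewhere. A read-out at one concentration also leaves the potency of all three compounds open.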